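The compounds below may be only part of what the source reports. "The series", "measured", "known", "first", "only" and "open" are said of these compounds alone.

Working notes on the series. In an ADME assay on PBMC cells (Homo sapiens) for cytotoxicity (a higher number here means that more compound is tolerated, a lower number that less compound is tolerated), compound 1 (`CC(CCNC(=O)c1c(Cl)cncc1Cl)N1CCC(C(Oc2ccncc2)c2ccc(Br)cc2)CC1`) gives 31200 nM and compound 2 (`COc1cccc(OC(c2ccc(C(F)(F)F)cc2)C2CCN(C(C)CCNC(=O)c3c(Cl)cncc3Cl)CC2)n1`) gives 32700 nM, so compound 2 stands within the scatter of compound 1. Compound 3 (`CCO/N=C(/c1ccc(Br)cc1)C1CCN(C(CC)CCNC(=O)c2c(C)cc[n+]([O-])c2C)CC1`) reads > 177000 nM, and this is a limit of the assay, not a number.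

Compound 4 (`CC(CCNC(=O)c1c(Cl)cncc1Cl)N1CCC(C(Oc2cccc(C(F)(F)F)c2)c2ccc(C(F)(F)F)cc2)CC1`) differs from compound 2 in one place: 3-(trifluoromethyl)phenyl in place of 6-methoxypyridin-2-yl on an oxygen on a saturated carbon. This puts 3-(trifluoromethyl)phenyl in place of 6-methoxypyridin-2-yl on an oxygen on a saturated carbon. Going by the values given here, no measured pair isolates a single change of this kind. Compound 1 carries a different group on that oxygen from compound 2 and differs elsewhere too, yet compound 1 gives 31200 nM, so only a small effect on this assay is expected. The expected step of a 1.5-fold lower number from compound 2 to compound 4 (0.17 log units; within the scatter) is a modest one toward less compound tolerated, and it may stay within the scatter. For compound 4 the estimated value is 22000 nM, with an expected range of 9000 nM to 50000 nM.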

Compound 4, half-maximal cytotoxic concentration: 7000 nM
The estimate for compound 4 lay 3.1-fold (0.50 log units) above the measured number, and the stated range ends above it.
By their numbers in this assay, from the lowest: compound 4; then compounds 1 and 2 (each within the scatter of the next). At a limit, above all of these: compound 3.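

In this assay, going by these compounds alone, the group on this oxygen is not a neutral choice: 3-(trifluoromethyl)phenyl in place of 6-methoxypyridin-2-yl gives a 4.7-fold lower number from compound 2 to compound 4 (0.67 log units; beyond the scatter) and is the only single-place step read so far. Compound 1 and compound 2 differ in more than one place, so their close numbers could not isolate this position, whereas this pair does. No measurement shown speaks to the cause of this step.

As far as these compounds go, the change swaps the ring and its substituent at once, so it remains open whether the lower number follows the trifluoromethyl group, the loss of the methoxy group or the loss of the ring nitrogen. A plain phenyl group on that oxygen, or a phenyl ring carrying an amine or a carboxylic acid, would help to separate these parts.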